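The source may hold more compounds than are shown below. What is called first, only, known or untested is meant among the compounds shown, and "the series" means these compounds.

Measured in a physicochemical assay for acid dissociation, read by capillary electrophoresis, so far:
- compound 1 `C[C@@]1(c2cc(NC(=O)c3ccc(C#N)cn3)ccc2F)Cc2c(ccnc2F)C(N)=N1` gives 8.2
- compound 2 `CC1(c2cc(NC(=O)c3ccc(C#N)cn3)ccc2F)Cc2c(ccnc2F)C(N)=N1` gives "not determined" (no result reported)

Compound 2 has no single number, so compound 1 at 8.2 is the nearest guide, given the fact that one of compounds 1 and 2 is drawn with a defined configuration and the other without, at the place where they differ and no reading of its own.

Compound 3 `CC1(c2cc(NC(=O)c3ccc(C#N)cn3)ccc2F)Cc2cnccc2C(N)=N1` is still unmeasured. The change is hydrogen in place of fluoro on an aromatic carbon with hydrogen in place of fluoro on an aromatic carbon. For the measured compounds named here, no measured step shows this change. In this assay a moderate upward step beyond the scatter is expected. Compound 3 is expected at 8.9 with an estimated range from 8.4 to 9.4 in this assay.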

Compound 3, acid dissociation constant: 9
For compound 3 the middle estimate is 0.10 log units below the measured one; measured number inside the range.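

For the compounds shown here, compound 3 gives 9 in this assay, but compound 2 has no single number, so no step to compound 3 can be read. On these data alone, what hydrogen in place of fluoro does on its own stays open.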